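Aminothiophene ketones at the adenosine A3 receptor: series notes

The source may report more compounds than this note shows. Statements on the series, on what has been measured and on what is new or still open speak of the compounds shown alone.

Measured in an assay on CHO cells for displacement of a labelled ligand from adenosine receptor A3 (Homo sapiens), read by scintillation counting, tested at 10 uM; a higher number here means more inhibition at the concentration tested (going by the name of the read-out), a lower number less inhibition:
compound 1 `Nc1sc(-c2ccccc2)c(-c2ccccc2)c1C(=O)c1ccc(Cl)cc1`: 1%
compound 2 `CC(C)(C)Cc1c(/C=C/c2ccc(Cl)cc2)sc(N)c1C(=O)c1ccc(Cl)cc1`: 11%
compound 3 `Cc1ccc(C(=O)c2c(CC(C)(C)C)csc2N)cc1`: 1%

Compound 2 has the highest of the three numbers, yet both compound 1 and compound 3 sit within the usual scatter of it, so no order among the three is claimed and the three numbers are taken as level. Within the data shown here, no pair of measured compounds differs in only one place, so no step size is known from the set itself.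

Compound 4 `CC(C)(C)Cc1c(-c2cccs2)sc(N)c1C(=O)c1ccc(Cl)cc1` is the next compound for this assay. Against compound 2 it shows (thiophen-2-yl in place of 2-(4-chlorophenyl)ethenyl on an aromatic carbon). Among the measured compounds shown here, with all three measured numbers low and no measured step to lean on, the step from compound 2 to compound 4 in this assay is expected to be a number 5 percentage points lower from compound 2 to compound 4 (within the scatter), that is, none beyond the scatter. Compound 4 is therefore estimated at 6%, with a range from -5% to 20%.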

Compound 4, a percentage reported as inhibition, at one concentration (the size of the read-out at that concentration, not a potency): 1%
The estimate for compound 4 lay 5 percentage points above the measured number; measured number inside the range.
By their numbers in this assay, from the lowest: compounds 1, 3, 4 and 2 (each within the scatter of the next).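

In this assay, among these compounds, the only single-place comparison reads a number 10 percentage points lower from compound 2 to compound 4 (within the scatter) and so counts as level. At this position, next to the ring sulfur, thiophen-2-yl and 2-(4-chlorophenyl)ethenyl therefore cannot be told apart, even though the second carries the six-membered aromatic ring, the chlorine and the double bond. No evidence on the cause of this result is available.

Open, from the compounds shown here alone, is whether any group here gives a number clear of the scatter, for example an amine, a carboxylic acid or a longer chain. Also open, going by these compounds, is whether replacing the neopentyl group with a cyclohexyl ring changes the reading.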